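This account rests on a few compounds, and the source may have more. Where it says the series, first, only, none or still open, it means among the compounds named here.

Measured so far in a functional assay on HEK293 cells for agonist activity at Neuronal acetylcholine receptor; alpha4/beta2 (Homo sapiens), read by FLIPR; on this read-out higher numbers stand for an effect only at larger amounts of compound and lower numbers for an effect already at smaller amounts:

compound 1 `c1cncc(N2C[C@@H]3CCNC[C@@H]32)c1` gives 410 nM
compound 2 `Clc1ccc(N2C[C@@H]3CCNC[C@@H]32)cn1` gives 37.4 nM

Compound 1 stands at the highest of the two numbers; its nearest neighbour is compound 2, reached by the step of an 11-fold lower number from compound 1 to compound 2 (1.04 log units; beyond the scatter).

Compound 3 `N#Cc1cncc(N2C[C@@H]3CCNC[C@@H]32)c1` differs from compound 1 by cyano in place of hydrogen on an aromatic carbon.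

Among the measured compounds shown here, only one measured step bears on this change, and it is the large one from compound 1 to compound 2, where a chloro replaced a hydrogen on an aromatic carbon of the same core; as the two structures show, that chloro and the cyano of compound 3 do not sit on the same ring carbon, so the step of an 11-fold lower number from compound 1 to compound 2 (1.04 log units; beyond the scatter) is only a loose guide. The single-heavy-atom halogen and the two-heavy-atom cyano are also different substituents. The expectation for compound 3 in this assay is therefore a moderate step downward, a 2.1-fold lower number from compound 1 to compound 3 (0.31 log units; beyond the scatter), with wide uncertainty. The estimated value for compound 3 is 200 nM, with a range from 50 nM to 800 nM.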

Compound 3, half-maximal effective concentration: 2190 nM
Compound 3: the middle estimate sits 11-fold (1.04 log units) below what was measured; the whole stated range lies below it.
By their numbers in this assay, from the lowest: compound 2; then compound 1; then compound 3.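

In this assay, cyano in place of hydrogen on an aromatic carbon two atoms from the ring nitrogen gives a 5.3-fold higher number from compound 1 to compound 3 (0.73 log units; beyond the scatter) and so shows that adding a group to this ring of the shared core does not by itself lower the number. Against an 11-fold lower number from compound 1 to compound 2 (1.04 log units; beyond the scatter) the change runs the opposite way, yet chloro and cyano sit on different ring carbons, so these compounds do not separate the effect of the group from that of its place. Nothing available here bears on why the number rises at this position.

Still open, going by these compounds, is whether chloro on the carbon now carrying cyano would follow compound 3 or compound 2. Also open, on these data alone, is how a methoxy group or an amine would behave on that same carbon.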